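The source may hold more compounds than are shown below. What is called first, only, known or untested is meant among the compounds shown, and "the series" means these compounds.

Among the compounds with values here, compound 2 `Cc1cc(C#N)cc(C)c1Oc1nc(Nc2ccc(C#N)cc2)ncc1-c1ccc(N)cc1` holds the lower of the two numbers measured so far in an ADME assay on MT4 cells (Homo sapiens) for cytotoxicity, read by MTT assay, with a stated time of 5 days; on this read-out lower numbers stand for higher toxicity in this test and higher numbers for lower toxicity in this test: compound 2 gives 310 nM, whereas compound 1 `Cc1cc(C)cc(-c2cnc(Nc3ccc(C#N)cc3)nc2Oc2c(C)cc(C#N)cc2C)c1` gives 39000 nM. Within the data shown here, the one measured step, a 130-fold lower number from compound 1 to compound 2 (2.10 log units; beyond the scatter), changes only the group on the same aromatic carbon and shows how strongly that group can move the read-out. Compound 3 `Cc1cc(C#N)cc(C)c1Oc1nc(Nc2ccc(C#N)cc2)ncc1-c1cccnc1` differs from compound 2 by pyridin-3-yl in place of 4-aminophenyl on an aromatic carbon. Among the measured compounds shown here, this exchange is not the measured one, but it removes the group that accompanied the lowest number, so a shift back toward a higher number is expected, though of uncertain size since no measured compound carries the entering group. Compound 3 is therefore estimated at 3000 nM, with a range from 700 nM to 15000 nM, which corresponds to an expected step of a 9.7-fold higher number from compound 2 to compound 3 (0.99 log units; beyond the scatter).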

Compound 3, half-maximal cytotoxic concentration: 13500 nM
Compound 3: middle estimate off by 4.5-fold (0.65 log units), on the low side; measured number inside the range.
By their numbers in this assay, from the lowest: compound 2; then compound 3; then compound 1.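

In this assay, pyridin-3-yl in place of 4-aminophenyl gives a 44-fold higher number from compound 2 to compound 3 (1.64 log units; beyond the scatter), so the low number of compound 2 does not carry over to every nitrogen-containing aromatic ring on this carbon. Pyridin-3-yl in place of 3,5-dimethylphenyl gives a 2.9-fold lower number from compound 1 to compound 3 (0.46 log units; beyond the scatter), a modest step though beyond the scatter, which makes 4-aminophenyl the group that stands apart among the three, while the other two lie much closer together. Nothing measured here explains these differences.

From the compounds shown here alone, it remains open whether the amino group itself goes with the low number, or whether its place on the ring also matters. A plain phenyl, a 3-aminophenyl or a 4-hydroxyphenyl on this carbon would help separate these possibilities.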